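The source may hold more compounds than are shown below. What is called first, only, known or untested is meant among the compounds shown, and "the series" means these compounds.

In a functional assay on MDA-MB-231 cells (Homo sapiens) for cytotoxicity, read by MTT assay, with a stated time of 48 h (a lower number here means a stronger inhibitor, a higher number a weaker inhibitor), the measured compounds stand as follows:
- compound 1 `Cc1nc(-c2c[nH]c3ccccc23)co1`: 103000 nM
- compound 2 `Fc1ccc(-c2nc(-c3c[nH]c4ccccc34)co2)cc1`: 90400 nM
- compound 3 `C=Cc1nc(-c2c[nH]c3ccccc23)co1`: 103000 nM

Compound 3 sits level with compound 1, the two together giving the highest numbers of the three. Its nearest neighbour is compound 1, with no change at the digits printed from compound 1 to compound 3 (within the scatter); its furthest is compound 2, with a 1.1-fold higher number from compound 2 to compound 3 (0.06 log units; within the scatter). The three numbers thus lie in a narrow band, and none of the three steps among them reaches beyond the scatter.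

The next compound, compound 4 `c1ccc2c(-c3coc(C4CCNCC4)n3)c[nH]c2c1`, differs from compound 3 in one place: piperidin-4-yl in place of vinyl on an aromatic carbon.

Three steps at this same position are on hand: a 1.1-fold lower number from compound 1 to compound 2 (0.06 log units; within the scatter), no change at the digits printed from compound 1 to compound 3 (within the scatter) and a 1.1-fold higher number from compound 2 to compound 3 (0.06 log units; within the scatter). Each swaps one small group for another at the same carbon, and each stays within the scatter, so the position has so far tolerated methyl, vinyl and 4-fluorophenyl without any shift in this assay. Among the measured compounds shown here, none of these steps brings in a non-aromatic ring or a hydrogen-bond donor, so no measured step covers a piperidin-4-yl directly, and the expectation rests on the flatness of the series rather than on a close precedent.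

On that basis compound 4 is expected to stay close to compound 3, with a 1.0-fold lower number from compound 3 to compound 4 (0.01 log units; within the scatter) as the estimated step and no direction beyond the scatter. The estimate for compound 4 is 100000 nM, with a range from 40000 nM to 250000 nM.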

Compound 4, half-maximal inhibitory concentration: 528000 nM
The estimate for compound 4 lay 5.3-fold (0.72 log units) below the measured number, and the stated range ends below it.
By their numbers in this assay, from the lowest: compounds 2, 1 and 3 (each within the scatter of the next); then compound 4.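

The step of a 5.1-fold higher number from compound 3 to compound 4 (0.71 log units; beyond the scatter) in this assay is matched by a 5.1-fold higher number from compound 1 to compound 4 (0.71 log units; beyond the scatter) and by a 5.8-fold higher number from compound 2 to compound 4 (0.77 log units; beyond the scatter) at the same aromatic carbon, so all three earlier groups give way to piperidin-4-yl in the same direction. This position, flat across methyl, vinyl and 4-fluorophenyl, therefore does not accept every group alike, and compound 4 is the weakest of the four compounds in this series. Piperidin-4-yl is the only group shown that brings both a six-membered non-aromatic ring and a hydrogen-bond donor, and no measured evidence at hand accounts for the rise.

On these data alone, the non-aromatic ring and the ring nitrogen enter together in this one change, so their separate contributions remain open: cyclohexyl at this carbon, or piperidin-4-yl with its nitrogen carrying a methyl or acetyl group, would pull them apart. Also open, as far as these compounds go, is whether an open-chain amine such as 2-aminoethyl, or a carboxylic acid, at the same carbon would follow compound 4 or stay with compounds 1, 2 and 3.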